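Notes on a small diaryl ethane series

This account rests on a few compounds, and the source may have more. Where it says the series, first, only, none or still open, it means among the compounds named here.

Compounds and values:
compound 1, `CCC(c1ccc(O)c(OC)c1)c1ccccc1O`, 10500 nM
compound 2, `CCC(c1ccc(O)c(OC)c1)c1cccc(O)c1O`, 6170 nM
compound 3, `CCC(c1ccc(O)c(OC)c1)c1cccc(C(C)C)c1O`, not yet measured

Among the compounds with values here, in a functional assay, with a stated time of 40 min (on this read-out lower numbers stand for stronger inhibition and higher numbers for weaker inhibition), compound 2 gives 6170 nM, the lower of the two numbers so far, though its step from compound 1 is a 1.7-fold lower number from compound 1 to compound 2 (0.23 log units; within the scatter). Compound 3 differs from compound 2 by isopropyl in place of hydroxy on an aromatic carbon. Within the data shown here, no measured step exchanges a hydroxy for an alkyl group, so the only guide is the small size of a 1.7-fold lower number from compound 1 to compound 2 (0.23 log units; within the scatter). The change is therefore expected to stay within scatter, a 1.1-fold higher number from compound 2 to compound 3 (0.05 log units; within the scatter). Compound 3 is estimated at 7000 nM, between 2500 nM and 20000 nM.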

Compound 3, half-maximal inhibitory concentration: 10100 nM
Compound 3: the middle estimate sits 1.4-fold (0.16 log units) below what was measured; measured number inside the range.
By their numbers in this assay, from the lowest: compounds 2, 3 and 1 (each within the scatter of the next).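

In this assay, the position now holds hydrogen, hydroxy and isopropyl with no separation among them (a 1.6-fold higher number from compound 2 to compound 3 (0.21 log units; within the scatter); a 1.0-fold lower number from compound 1 to compound 3 (0.02 log units; within the scatter)). Exchanging hydroxy for isopropyl removes a hydrogen-bond donor and acceptor and adds heavy atoms, yet the step stays within the scatter, so neither feature shows a measurable link to the read-out here. No supporting evidence bears on this result.

Going by these compounds, whether an amine, a carboxylic acid or a longer chain at this position would give a step beyond the scatter remains open.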